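The compounds below may be only part of what the source reports. "The series", "measured", "known", "first", "only" and "open" are said of these compounds alone.

In a functional assay on cells (T-cell, Homo sapiens) for inhibition (a lower number here means a stronger inhibitor, a higher number a weaker inhibitor), compound 2 `COc1ccc(-c2cnc3nc(N)nc(N4CCN(C(=O)Nc5ccc(C)cc5)CC4)c3n2)cc1OC` gives 0.8 nM, the lower of the two numbers measured here. Compound 3 `COc1ccc(-c2cnc3nc(N)nc(OC(C)C)c3n2)cc1OC` gives 400 nM in this assay, a gap far beyond the usual scatter. Compound 1 `CC(C)Oc1nc(N)nc2ncc(-c3ccc(C#N)cc3)nc12` reaches only (the limit of > 10000 nM in this assay, at which 1 of the 3 values shown sits), reported as > 10000 nM, which is a limit of the assay and not a number.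

Compound 4 `COc1ccc(-c2cnc3nc(N)nc(N4CCN(C(=O)Nc5cccc(C)c5)CC4)c3n2)cc1OC` differs from compound 2 in one place: 3-methylphenyl in place of 4-methylphenyl on an amide-type nitrogen. For the measured compounds named here, no measured pair shows this kind of change, so the expected step of a 1.9-fold higher number from compound 2 to compound 4 (0.27 log units; within the scatter) is small, probably within the scatter, with at most a slight weakening. The estimate for compound 4 in this assay is therefore 1.5 nM, in a range from 0.5 nM to 5 nM.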

Compound 4, half-maximal inhibitory concentration: 7 nM
For compound 4 the middle estimate is 4.7-fold (0.67 log units) below the measured one; measured number outside the range, above it.
By their numbers in this assay, from the lowest: compound 2; then compound 4; then compound 3. At a limit, above all of these: compound 1.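

In this assay, for the compounds shown here, 3-methylphenyl in place of 4-methylphenyl on an amide-type nitrogen gives an 8.8-fold higher number from compound 2 to compound 4 (0.94 log units; beyond the scatter), the first pair here that differs in one place. Both groups have the same atoms, so this site responds to where the methyl sits, not only to which atoms are present. Nothing shown here accounts for the size of this step.

Still open, going by these compounds, is how plain phenyl, 4-chlorophenyl or cyclohexyl would behave on this nitrogen. On these data alone, whether the same change would give a similar step on another core is also open.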